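The compounds below may be only part of what the source reports. "The series", "measured", "known", "first", "only" and "open" are said of these compounds alone.

Of the compounds shown here, three have been tested so far in an ADME assay on HCT-116 cells (Homo sapiens) for cytotoxicity, read by CellTiter-Glo, with a stated time of 72 h (a higher number here means a weaker inhibitor, a lower number a stronger inhibitor), and none gives an exact number. Compound 1 `Cc1cc(C)c(S(=O)(=O)N2CCN(C3CCN(C)CC3)CC2)c(C)c1` gives > 5000 nM as a limit of the assay. Compound 2 `Cc1ccc(S(=O)(=O)N2CCC(N3CCC(C)CC3)CC2)cc1C` gives > 5000 nM as a limit too. Compound 3 `CC1CCN(C2CCN(S(=O)(=O)c3ccccc3-c3ccc(C(F)(F)F)cc3)CC2)CC1` gives > 5000 nM as a limit again. Compound 2 therefore has only a limit, which it shares with both others. Compound 4 `Cc1nc(Cl)sc1S(=O)(=O)N1CCC(N2CCC(C)CC2)CC1` differs from compound 2 in one place, counted as 2-chloro-4-methyl-1,3-thiazol-5-yl in place of 3,4-dimethylphenyl on a sulfonyl sulfur and putting 2-chloro-4-methyl-1,3-thiazol-5-yl in place of 3,4-dimethylphenyl on a sulfonyl sulfur. Among the measured compounds shown here, with compound 2 at the limit of > 5000 nM in this assay, at which 3 of the 3 values shown sit, and no measured step to go on, no step beyond the scatter is expected in this assay here. The estimated change is a step that the limit leaves unreadable from compound 2 to compound 4 and remains only an expectation. Compound 4 is estimated at 6000 nM with an expected range from 2500 nM to 15000 nM and may well return only a limit.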

Compound 4, half-maximal inhibitory concentration: > 10000 nM
Compound 4: no number, only a limit; the forecaster's own chance of this, stated with the estimate: 80%; at least 1.6-fold (0.22 log units) between middle value and limit.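

Compound 2 and compound 4 both return only a limit in this assay, so no step can be read between them. The compounds shown leave open which change in structure would give an exact number.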